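A few compounds are considered here, and "the series" means these few. Any claim that something is new, unique, unknown or untested is made for them only; others in the source may bear on it.

Working notes on the series in an assay on cells for inhibition of MAP kinase-interacting serine/threonine-protein kinase 1 (Homo sapiens), read by mobility shift assay, with stated times of 10 min and 60 min, in the presence of a further agent that is not named here; a lower number here means a stronger inhibitor, a higher number a weaker inhibitor.

Three compounds have numbers. Compound 1 `CNC(=O)c1cncc(-c2ccc(C(N)=O)c(OC(C)C)c2)c1` gives 1900 nM in this assay. Going by the values given here, compound 3 `Cc1n[nH]c(C)c1-c1cncc(-c2ccc(C(N)=O)c(OC(C)C)c2)c1` gives 33 nM, and the single step that changes one place, a 58-fold lower number from compound 1 to compound 3 (1.76 log units; beyond the scatter), is the only measured step in the set. Compound 2 `NCCOc1cc(-c2cccnc2)ccc1C(N)=O` gives 820 nM and stands second highest of the three numbers, nearer to compound 1 than to compound 3.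

Compound 4 `CCNc1cc(-c2cccnc2)ccc1C(N)=O` is not yet measured. The change from compound 2 is ethylamino in place of 2-aminoethoxy on an aromatic carbon, on the aromatic carbon ortho to the carbamoyl group and meta to the pyridin-3-yl group. Among the compounds with values here, the one measured step alters a different place, the substituent on the pyridine, so nothing measured bears directly on this change; the shared core is kept and the number of donors on the chain is unchanged. Compound 4 is therefore expected to stay close to compound 2, with no step beyond the scatter in either direction, a 1.2-fold higher number from compound 2 to compound 4 (0.09 log units; within the scatter). The estimate for compound 4 in this assay is 1000 nM, with a range from 300 nM to 3500 nM.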

Compound 4, half-maximal inhibitory concentration: 58000 nM
The estimate for compound 4 lay 58-fold (1.76 log units) below the measured number, outside the stated range (above it).
By their numbers in this assay, from the lowest: compound 3; then compound 2; then compound 1; then compound 4.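

In this assay, the aromatic carbon ortho to a carbamoyl group proves highly sensitive to the chain it carries, with a 71-fold higher number from compound 2 to compound 4 (1.85 log units; beyond the scatter) when ethylamino replaces 2-aminoethoxy. The counted difference is small: heavy atoms go from 4 to 3 and hydrogen-bond acceptors from 2 to 1, while the count of 1 hydrogen-bond donor and the absence of net charge stay the same, so a matched donor count does not keep the number close here. No supporting measurement is available to explain the size of this step.

The compounds shown leave open whether the difference follows the ether oxygen, the terminal amine or the chain length at this carbon. A 2-aminoethylamino chain or an ethoxy group here would separate these features.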